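This account rests on a few compounds, and the source may have more. Where it says the series, first, only, none or still open, it means among the compounds named here.

Values in a functional assay on HeLa cells (Homo sapiens) for antiproliferative activity, read by sulforhodamine B assay, with a stated time of 72 h; on this read-out higher numbers stand for weaker inhibition and lower numbers for stronger inhibition:
- Compound 1 `COc1ccccc1NC(=S)N/N=C/c1ccc2ccccc2n1`: > 100000 nM, a limit of the assay and not a number
- Compound 2 `N#Cc1ccc(NC(=S)N/N=C/c2ccc3ccccc3n2)cc1`: 20000 nM
- Compound 3 `NC(=S)N/N=C/c1ccc2ccccc2n1`: 960 nM

Compound 3 has the lowest number shown, 960 nM. Compound 4 `Fc1ccc(NC(=S)N/N=C/c2ccc3ccccc3n2)cc1` differs from it by one change, 4-fluorophenyl in place of hydrogen on an amide-type nitrogen. Among the measured compounds shown here, two measured steps bear on this change, both large and both running from a ring-bearing compound to compound 3: a 21-fold lower number from compound 2 to compound 3 (1.32 log units; beyond the scatter) and an at least 100-fold lower number from compound 1 to compound 3 (2.01 log units; beyond the scatter). Adding the ring to compound 3 is therefore expected to reverse that direction, with a large rise in this assay. The expected change is a 16-fold higher number from compound 3 to compound 4 (1.19 log units; beyond the scatter). Compound 4 is estimated at 15000 nM, with an expected range of 3000 nM to 80000 nM.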

Compound 4, half-maximal inhibitory concentration: 33200 nM
Beside the measured number, compound 4's estimate is 2.2-fold (0.35 log units) below it; measured number inside the range.
By their numbers in this assay, from the lowest: compound 3; then compounds 2 and 4 (each within the scatter of the next). At a limit, above all of these: compound 1.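

With 4-fluorophenyl in place of hydrogen on the amide-type nitrogen, the penalty for a ring-bearing group is now seen directly, as a 35-fold higher number from compound 3 to compound 4 (1.54 log units; beyond the scatter). The substituent on that ring matters less between the two para-free comparisons available: fluoro in place of cyano on an aromatic carbon gives a 1.7-fold higher number from compound 2 to compound 4 (0.22 log units; within the scatter), so this swap shows no real change. The step of an at least 3.0-fold lower number from compound 1 to compound 4 (0.47 log units; beyond the scatter) rests on compound 1's value, which is a limit and not a number: the limit of > 100000 nM in this assay, at which 1 of the 4 values shown sits.

Still open, going by these compounds, is whether methyl or a longer alkyl chain on that nitrogen would keep the low number of compound 3. Also open, on these data alone, is how an amine or a carboxylic acid on the phenyl ring would read.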